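The source may report more compounds than this note shows. Statements on the series, on what has been measured and on what is new or still open speak of the compounds shown alone.

Of the compounds shown here, three with a shared core have been measured in a functional assay on MCF-10A cells (Homo sapiens) for antiproliferative activity, with a stated time of 48 h; on this read-out higher numbers stand for an effect only at larger amounts of compound and lower numbers for an effect already at smaller amounts. Compound 1 `COc1ccc2nc(C)cc(NCc3ccccc3)c2c1` gives 28600 nM, compound 2 `COc1ccc2nc(C)cc(NCc3ccc(C(F)(F)F)cc3)c2c1` gives 7600 nM, and compound 3 `COc1ccc2nc(C)cc(NCc3ccc(F)cc3C(F)(F)F)c2c1` gives 4200 nM. Compound 2 therefore sits clearly under compound 1 and within the usual scatter of compound 3.

Compound 4 `COc1ccc2nc(C)cc(NCc3ccc(N(C)C)cc3)c2c1` departs from compound 2 in one place, with dimethylamino in place of trifluoromethyl on an aromatic carbon. Among the measured compounds shown here, only one measured step involves a change at that carbon: a 3.8-fold lower number from compound 1 to compound 2 (0.58 log units; beyond the scatter), a modest step beyond the scatter, in which trifluoromethyl took the place of hydrogen. For the measured compounds named here, it shows that a change at this carbon can move the number, but no measured compound carries dimethylamino, so the evidence is indirect. Losing trifluoromethyl may give back part of that step, though probably not all of it. The expected change is a 2.1-fold higher number from compound 2 to compound 4 (0.32 log units; beyond the scatter), towards a higher number, and it is uncertain. Compound 4 is estimated at 16000 nM, with an expected range from 5500 nM to 42000 nM.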

Compound 4, half-maximal effective concentration: 20000 nM
The estimate for compound 4 lay 1.3-fold (0.10 log units) below the measured number; low and high end bracket the measured number.
By their numbers in this assay, from the lowest: compounds 3 and 2 (each within the scatter of the next); then compounds 4 and 1 (each within the scatter of the next).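

In this assay, this carbon now has a second group to set against trifluoromethyl, and the two are not interchangeable: dimethylamino in place of trifluoromethyl gives a modest step beyond the scatter (a 2.6-fold higher number from compound 2 to compound 4 (0.42 log units; beyond the scatter)). Measured against hydrogen at the same carbon, dimethylamino gives a step that stays within the scatter (a 1.4-fold lower number from compound 1 to compound 4 (0.16 log units; within the scatter)), so the lower number seen with trifluoromethyl does not appear with dimethylamino. Nothing measured here explains why these two groups differ.

From the compounds shown here alone, whether another group at this carbon, such as a nitrile or a carboxylic acid, would fall with trifluoromethyl or with dimethylamino remains open. Also open, going by these compounds, is whether a plain amine in place of dimethylamino would likewise stay within the scatter of compound 1.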